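Compound 3 in the cytotoxicity series: working notes

This account rests on a few compounds, and the source may have more. Where it says the series, first, only, none or still open, it means among the compounds named here.

Measured in a toxicity assay on NIH3T3 cells (Mus musculus) for cytotoxicity, read by resazurin assay (a higher number here means that more compound is needed for the effect, a lower number that less compound is needed), so far:
- compound 1 `COC(=O)c1ccc(NCc2cncn2Cc2ccc(Cl)cc2)cc1-c1ccccc1`: 25000 nM
- compound 2 `COC(=O)c1ccc(NCc2cncn2Cc2cccc(N)c2)cc1-c1ccccc1`: > 10000 nM (a limit, not a number)

For compound 2 there is only the limit of > 10000 nM in this assay, at which 1 of the 2 values shown sits, and no number, so its place in this assay cannot be fixed any closer. Compound 3 `COC(=O)c1ccc(NCc2cncn2Cc2ccccc2C#N)cc1-c1ccccc1` has not been measured. The change is 2-cyanophenyl in place of 3-aminophenyl on a saturated chain carbon bound to an aromatic nitrogen and reads, in words, 2-cyanophenyl in place of 3-aminophenyl on a saturated chain carbon bound to an aromatic nitrogen, or 3-aminobenzyl to 2-cyanobenzyl.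

Within the data shown here, one measured step bears on this place. It is a step that the limit leaves unreadable from compound 1 to compound 2 and gives no size to carry over. In this assay, among the measured compounds shown here, compound 1 gives 25000 nM as the sole readable number, and the expectation leans on that value. No direction can be argued from these data, so the expected change is modest and uncertain, estimated as a step that the limit leaves unreadable from compound 2 to compound 3 and no more than that. A further limit reading would be no surprise. Compound 3 is expected near 20000 nM (estimated range 8000 nM to 60000 nM).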

Compound 3, half-maximal effective concentration: 25000 nM
The estimate for compound 3 lay 1.3-fold (0.10 log units) below the measured number; the measured number falls inside the stated range.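

In this assay, among these compounds, the place on a saturated chain carbon bound to an aromatic nitrogen now has two readable numbers, and 2-cyanophenyl in place of 4-chlorophenyl there gives no change at the digits printed from compound 1 to compound 3 (within the scatter). 2-Cyanophenyl brings a triple bond outside aromatic rings that 4-chlorophenyl lacks, yet the read-out does not separate these two groups, which is the first readable comparison at this place. Compound 2 gives > 10000 nM, a limit and not a number, and the steps that touch it cannot be read: the limit of > 10000 nM in this assay, at which 1 of the 3 values shown sits.

From the compounds shown here alone, whether any group at this place can move the number in this assay beyond the scatter stays open, as one readable step with no change cannot settle that for groups outside these two. Also open, going by these compounds, is how a carboxylic acid or a longer chain carrying an amine would read at this place, and whether 3-aminophenyl, known here only through its limit, differs at all from 2-cyanophenyl and 4-chlorophenyl.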